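Series notes: from compound 2 to compound 4

The source may report more compounds than this note shows. Statements on the series, on what has been measured and on what is new or still open speak of the compounds shown alone.

Compound 2 `O=C1O[C@H]([C@@H](O)Cn2cc(CNS(=O)(=O)c3ccc(F)cc3)nn2)C(OCc2ccccc2)=C1OCc1ccccc1` carries a 4-fluorophenyl on the sulfonyl sulfur. In a functional assay on HepG2 cells (Homo sapiens) for antiproliferative activity, read by MTT assay, with a stated time of 72 h (on this read-out lower numbers stand for stronger inhibition and higher numbers for weaker inhibition), compound 2 gives 18300 nM, the lowest of the two numbers recorded, with compound 1 `O=C1O[C@H]([C@@H](O)Cn2cc(CNS(=O)(=O)c3ccc(Cl)cc3F)nn2)C(OCc2ccccc2)=C1OCc1ccccc1` nearest at 25500 nM. For the measured compounds named here, the single measured step, a 1.4-fold lower number from compound 1 to compound 2 (0.14 log units; within the scatter), is the only comparison of two numbers in this set. Compound 3 `O=C1O/C(=C\Cn2cc(-c3cc(C(F)(F)F)cc(C(F)(F)F)c3)nn2)C(OCc2ccccc2)=C1OCc1ccccc1` gives only a limit in this assay, > 100000 nM (the limit of > 100000 nM in this assay, at which 1 of the 3 values shown sits).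

Compound 4 `CCCCCc1ccc(-c2cn(C[C@H](O)[C@H]3OC(=O)C(OCc4ccccc4)=C3OCc3ccccc3)nn2)cc1` has not yet been measured. It differs from compound 2 in one place: 4-pentylphenyl in place of (((4-fluorophenyl)sulfonyl)amino)methyl on an aromatic carbon. Going by the values given here, no measured step covers this exchange; the step from compound 1 to compound 2 changes only the aryl on the sulfonyl sulfur and stays within the scatter, so it gives no direction. Among the compounds with values here, compound 3 offers no step either, and only its limit can be stated. The expectation for compound 4 is a weaker number, the expected step being a 2.2-fold higher number from compound 2 to compound 4 (0.34 log units; beyond the scatter). Compound 4 is therefore estimated near 40000 nM, within 12000 nM to 100000 nM, with a fair chance that only a limit is reported.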

Compound 4, half-maximal inhibitory concentration: 7460 nM
The estimate for compound 4 lay 5.4-fold (0.73 log units) above the measured number; the whole stated range lies above it.
By their numbers in this assay, from the lowest: compound 4; then compounds 2 and 1 (each within the scatter of the next). At a limit, above all of these: compound 3.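

In this assay, for the compounds shown here, 4-pentylphenyl in place of (((4-fluorophenyl)sulfonyl)amino)methyl on the aromatic carbon of the five-membered aromatic ring with 3 nitrogen gives a 2.5-fold lower number from compound 2 to compound 4 (0.39 log units; beyond the scatter), the first step in this set that lies beyond the scatter. This position therefore responds to a change of the whole substituent, which the exchange of aryl groups on the sulfonyl sulfur did not show, and compound 4 keeps its activity without the hydrogen-bond donor and acceptors of the leaving group. Nothing shown here gives a measured reason for this step.

The compounds shown do not separate the contribution of the pentyl chain from that of the phenyl ring set directly on the five-membered ring. An unsubstituted phenyl, a shorter propyl chain or a longer octyl chain at this place, or an amine at the end of the pentyl chain, would bear on that question.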